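Adding an ethoxy back onto the carbamate side chain

The source may report more compounds than this note shows. Statements on the series, on what has been measured and on what is new or still open speak of the compounds shown alone.

Of the compounds shown here, three that share one core have been measured in a functional assay on L1210 cells (Mus musculus), with a stated time of 1 days; on this read-out lower numbers stand for lower potency and higher numbers for higher potency (the scale is a negative logarithm). Compound 1 `CCOC(COC(N)=O)C1=C(N2CC2)C(=O)C(C)=C(N2CC2)C1=O` gives 4.62, compound 2 `CCC1=C(N2CC2)C(=O)C(C(COC(N)=O)OC)=C(N2CC2)C1=O` gives 4.92, and compound 3 `CCC1=C(N2CC2)C(=O)C(CCOC(N)=O)=C(N2CC2)C1=O` gives 4.88. These three numbers all lie within the usual scatter of one another, so compound 3 cannot be separated from compound 1 or compound 2 by potency on this evidence.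

Compound 4 `CCOC(COC(N)=O)C1=C(N2CC2)C(=O)C(CC)=C(N2CC2)C1=O` has not been measured. It differs from compound 3 in one place: ethoxy in place of hydrogen on a saturated chain carbon bound to a double-bonded ring carbon and a saturated chain carbon. Going by the values given here, only one measured step touches the same place on the chain, the one from compound 2 to compound 3, where a methoxy was replaced by hydrogen and the read-out moved by a number 0.04 log units lower from compound 2 to compound 3 (within the scatter), a shift inside the scatter. Compound 4 reverses the direction of that kind of change, putting an ethoxy where compound 3 carries hydrogen, so the natural expectation is a step of similar size, that is, none beyond the scatter. Compound 1 carries the same ethoxy as compound 4 and sits close to the others, which supports that expectation. The estimated step in this assay from compound 3 to compound 4 is therefore a number 0.03 log units lower from compound 3 to compound 4 (within the scatter), and compound 4 is expected to give about 4.85, most likely between 4.45 and 5.25.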

Compound 4, logarithm of the reciprocal of the active concentration, log(1/C): 4.64
For compound 4 the middle estimate is 0.21 log units above the measured one; low and high end bracket the measured number.
By their numbers in this assay, from the lowest: compounds 1, 4, 3 and 2 (each within the scatter of the next).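

In this assay, ethoxy in place of hydrogen on the saturated chain carbon bound to a double-bonded ring carbon and a saturated chain carbon gives a number 0.24 log units lower from compound 3 to compound 4 (within the scatter), and methyl in place of hydrogen on the saturated chain carbon bound to an oxygen on a saturated carbon, which turns methoxy into ethoxy, gives a number 0.28 log units lower from compound 2 to compound 4 (within the scatter). This chain carbon has now carried hydrogen, methoxy and ethoxy on an otherwise identical molecule, and neither new step leaves the scatter, so the read-out does not separate these three groups. The other single change, methyl in place of hydrogen on the saturated chain carbon bound to a double-bonded ring carbon, gives a number 0.02 log units higher from compound 1 to compound 4 (within the scatter), also inside the scatter, and nothing available here explains any of these steps.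

All of these steps concern small changes in one assay on one cell line, so they say little about groups of a different kind. As far as these compounds go, whether an amine, a carboxylic acid or a longer chain such as butoxy on the same chain carbon would shift the read-out beyond the scatter remains open.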